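The source may hold more compounds than are shown below. What is called first, only, known or untested is meant among the compounds shown, and "the series" means these compounds.

Of the compounds shown here, three sharing one core have been measured. Compound 1 `Cc1ccc(-c2cn(-c3ccc(CN4CCCC4)cc3)nn2)cc1Nc1nccc(-c2cccnc2)n1` gives 5420 nM in a functional assay on KG-1a cells (Homo sapiens) for inhibition, read by MTT assay, with a stated time of 72 h; a higher number here means a weaker inhibitor, a lower number a stronger inhibitor. Compound 2 `Cc1ccc(-n2cc(-c3ccc(CN4CCN(C)CC4)c(C(F)(F)F)c3)nn2)cc1Nc1nccc(-c2cccnc2)n1` gives 1270 nM in this assay. Compound 3 `Cc1ccc(-c2nnc(-c3ccc(CN4CCN(C)CC4)cc3)o2)cc1Nc1nccc(-c2cccnc2)n1` gives 1780 nM in this assay, the second highest of the three numbers; its gap to compound 2 lies within the scatter, while its gap to compound 1 lies beyond it, compound 1 having the higher number. Compound 4 `Cc1ccc(-c2nnc(-c3ccc(CN4CCN(C)CC4)c(C(F)(F)F)c3)o2)cc1Nc1nccc(-c2cccnc2)n1` has not been measured. It differs from compound 3 by trifluoromethyl in place of hydrogen on an aromatic carbon. Compound 2 already carries a trifluoromethyl at 1270 nM and stands within the scatter of compound 3 at 1780 nM, so no step beyond the scatter is expected, perhaps a slight lowering. Compound 4 is therefore estimated at 1300 nM, between 500 nM and 3500 nM, an expected step of a 1.4-fold lower number from compound 3 to compound 4 (0.14 log units; within the scatter).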

Compound 4, half-maximal inhibitory concentration: 580 nM
For compound 4 the middle estimate is 2.2-fold (0.35 log units) above the measured one; the range from low to high includes it.
By their numbers in this assay, from the lowest: compound 4; then compounds 2 and 3 (each within the scatter of the next); then compound 1.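

In this assay, trifluoromethyl in place of hydrogen on the aromatic carbon ortho to the (4-methylpiperazin-1-yl)methyl group gives a 3.1-fold lower number from compound 3 to compound 4 (0.49 log units; beyond the scatter) and is a modest change. Within the data shown here, this is the only comparison here that differs in one place, so it alone shows that the number responds to a change at this position. Nothing given here accounts for the step. From the compounds shown here alone, whether a chlorine atom, a methoxy group or a nitrile at this position would give a similar step stays open.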